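A few compounds are considered here, and "the series" means these few. Any claim that something is new, unique, unknown or untested is made for them only; others in the source may bear on it.

In a functional assay (blood) for inhibition, with Homo sapiens as the target (a higher number here means a weaker inhibitor, a lower number a stronger inhibitor), compound 2 `C/C(=N\OCCF)c1ccc(Sc2cc(F)cc(C3CCOCC3)c2)cc1` gives 40 nM. Compound 1 `OC1O[C@H](CO/N=C2\CCc3cc(Sc4cc(F)cc(C5CCOCC5)c4)ccc32)[C@H](O)[C@H](O)[C@H]1O` returns only a limit of this assay, > 2500 nM, and of the two values shown one sits at that limit (the limit of > 2500 nM in this assay, at which 1 of the 2 values shown sits). Among the measured compounds shown here, compound 2 therefore holds the only actual number in this assay. Compound 3 `C/C(=N\OC(=O)N(C)C)c1ccc(Sc2cc(F)cc(C3CCOCC3)c2)cc1` is not yet measured; it differs from compound 2 by dimethylcarbamoyl in place of 2-fluoroethyl on an oxygen. The step from compound 2 to compound 3 in this assay is expected to be modest, toward weaker inhibition if any, and possibly within the scatter: a 2.0-fold higher number from compound 2 to compound 3 (0.30 log units; within the scatter). Compound 3 is estimated at 80 nM, within a range of 25 nM to 300 nM.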

Compound 3, half-maximal inhibitory concentration: 2610 nM
Compound 3: middle estimate off by 33-fold (1.51 log units), on the low side; measured number outside the range, above it.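

On an oxygen whose other neighbour is a double-bonded nitrogen, the group present strongly affects the read-out in this assay: dimethylcarbamoyl in place of 2-fluoroethyl gives a 65-fold higher number from compound 2 to compound 3 (1.81 log units; beyond the scatter). Among the compounds shown here, this is the first readable step, and it shows that this position is sensitive to substitution. Nothing shown accounts for the size of this step.

Still open, on these data alone, is whether the loss tracks the carbonyl or the dimethylamino part of the new group. Acetyl or plain ethyl on this oxygen would help separate the two.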